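Shortening the ether chain of compound 1

The compounds below may be only part of what the source reports. "The series", "measured", "known", "first", "only" and "open" are said of these compounds alone.

Of the compounds shown here, two have been measured so far. Compound 1 `CC(C)COc1ccc2c(Cl)ccnc2c1` gives 3190 nM in a functional assay on SK-OV-3 cells (Homo sapiens) for cytotoxicity, read by MTT assay, with a stated time of 48 h (on this read-out higher numbers stand for weaker inhibition and lower numbers for stronger inhibition), the lower of the two numbers. Compound 2 `C=CCOc1ccc2c(NCCCN(C)C)ccnc2c1` gives 4250 nM in this assay; the two values lie within the usual scatter of each other, so no order can be read between them. Compound 3 `CC(C)Oc1ccc2c(Cl)ccnc2c1` is not yet measured and differs from compound 1 by isopropyl in place of isobutyl on an oxygen on an aromatic ring. Among the measured compounds shown here, no measured pair shows what this change does; since only the shape of the ether chain changes, the expected step is a 1.2-fold higher number from compound 1 to compound 3 (0.08 log units; within the scatter), within the scatter and in no set direction. For compound 3 a value of 3800 nM is expected, with a range from 1500 nM to 10000 nM.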

Compound 3, half-maximal inhibitory concentration: 3060 nM
The estimate for compound 3 lay 1.2-fold (0.09 log units) above the measured number, and the stated range covers the measured number.
By their numbers in this assay, from the lowest: compounds 3, 1 and 2 (each within the scatter of the next).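

Replacing isobutyl with isopropyl on an oxygen on an aromatic ring gives a 1.0-fold lower number from compound 1 to compound 3 (0.02 log units; within the scatter) in this assay. This first measured pair at this position therefore shows that removing one carbon from the ether chain leaves the number within the scatter, so this change has no readable effect on this read-out. Nothing available explains this result. Still open, from the compounds shown here alone, is whether a much longer chain, a phenyl ring or an amine on this oxygen would move the number beyond the scatter.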